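Furan-3-yl in Place of Dihydroxyphenyl on the Dodecyl Ester

A few compounds are considered here, and "the series" means these few. Any claim that something is new, unique, unknown or untested is made for them only; others in the source may bear on it.

In a functional assay on the whole organism (strain CD1) for inhibition, with Mus musculus as the target, with stated times of 15 min and 20 min, at a dose of 10 mg/kg by the subcutaneous route (a lower number here means less inhibition, a higher number more inhibition at the dose given (going by the name of the read-out)), compound 1 `CCCCCCCCCCCCOC(=O)/C(C#N)=C/c1ccc(O)c(O)c1` gives 45.2%, the highest of the three numbers shown. Compound 3 `N#C/C(=C\c1ccoc1)C(=O)O` gives 30.7%, a result beyond the scatter below it, and compound 2 `Cc1ccc(/C=C(\C#N)C(=O)O)cc1C` gives -6.1%, further below still. Compound 4 `CCCCCCCCCCCCOC(=O)/C(C#N)=C/c1ccoc1` has not yet been measured in this assay. It differs from compound 1 by furan-3-yl in place of 3,4-dihydroxyphenyl on a double-bonded chain carbon bound to a double-bonded chain carbon. For the measured compounds named here, no step between measured compounds isolates this single change; compound 3 also carries furan-3-yl, but the rest of its structure differs from compound 4, so its value is only a loose guide. The expected step of a number 17.2 percentage points lower from compound 1 to compound 4 (beyond the scatter) is a decrease beyond the scatter. Compound 4 is estimated at 28%, within 5% to 50%.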

Compound 4, a percentage reported as inhibition, in the whole organism at one dose (the size of the read-out at that dose, not a potency): 53.8%
The estimate for compound 4 lay 25.8 percentage points below the measured number; the measured number lies above the stated range.
By their numbers in this assay, from the lowest: compound 2; then compound 3; then compounds 1 and 4 (each within the scatter of the next).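

In this assay, furan-3-yl in place of 3,4-dihydroxyphenyl on the dodecyl ester gives a number 8.6 percentage points higher from compound 1 to compound 4 (within the scatter). At this place, then, the dodecyl ester keeps its inhibition at the dose given without the six-membered ring and without the hydrogen-bond donors of the group that leaves. Nothing shown accounts for this result. The compounds shown leave open whether an unsubstituted phenyl or a thiophen-3-yl group would serve equally well at this place. They also leave open how a shorter chain, such as hexyl, in place of dodecyl would fare with furan-3-yl.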